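Notes on the step from compound 2 to compound 3

The source may hold more compounds than are shown below. What is called first, only, known or untested is meant among the compounds shown, and "the series" means these compounds.

Compound 1 `CCCC(=O)NCC(=O)N(C)c1ccc(Cl)cc1C(=O)c1ccccc1Cl` is the reference point of the pair measured so far: in a functional assay on the whole organism with Mus musculus as the target, in the rotarod test (a higher number here means that more compound is needed for the effect, a lower number that less compound is needed), compound 1 gives 55.2 mg/kg. Compound 2 `CN1CCN(CC(=O)NCC(=O)N(C)c2ccc(Cl)cc2C(=O)c2ccccc2Cl)CC1` gives in this assay only the limit > 100 mg/kg, so no number is known for it, and its value is one of those described by the limit of > 100 mg/kg in this assay, at which 1 of the 2 values shown sits. For the measured compounds named here, the single measured step, an at least 1.8-fold higher number from compound 1 to compound 2 (0.25 log units; that floor lies within the scatter), shows that bringing in the 4-methylpiperazin-1-yl group raised the dose needed to a point the assay no longer resolved.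

Compound 3 `CCC(=O)NCC(=O)N(C)c1ccc(Cl)cc1C(=O)c1ccccc1Cl` has not yet been measured in this assay. It differs from compound 2 by methyl in place of 4-methylpiperazin-1-yl on a saturated chain carbon bound to a carbonyl carbon. Going by the values given here, this change undoes the one measured step and goes one carbon further, leaving a propanoyl group that is close to the butanoyl group of compound 1. Since the step from compound 1 to compound 2 moved the dose upward to the limit, the reverse change is expected to bring the dose back down, and the estimate for compound 3 is 55 mg/kg in this assay, between 25 mg/kg and 110 mg/kg, which means an expected step of an at least 1.8-fold lower number from compound 2 to compound 3 (0.25 log units; that floor lies within the scatter).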

Compound 3, dose for half-maximal effect: 36 mg/kg
Compound 3: the middle estimate sits 1.5-fold (0.18 log units) above what was measured; the range from low to high includes it.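

In this assay, the exchange at the saturated chain carbon bound to a carbonyl carbon now gives a step that clears the scatter, which the earlier pair did not show: an at least 2.7-fold lower number from compound 2 to compound 3 (0.44 log units; beyond the scatter). As far as these compounds go, this separates the compound carrying 4-methylpiperazin-1-yl from a small acyl neighbour with a simple alkyl end, but compound 2 stands only at a limit, so the step is a floor and its full size remains unknown: the limit of > 100 mg/kg in this assay, at which 1 of the 3 values shown sits. The two simple acyl compounds cannot be told apart, since the difference between butanoyl and propanoyl stays within the scatter, a 1.5-fold lower number from compound 1 to compound 3 (0.19 log units; within the scatter), so this small shortening of the chain has no readable effect on the dose in this assay.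

The compounds shown leave open whether the higher dose of compound 2 goes with the 4-methylpiperazin-1-yl group specifically or with any amine at this place, such as dimethylamino or morpholin-4-yl. They also leave open how far the chain can be changed in either direction, from an acetyl group to a longer chain such as hexanoyl, before the dose in this assay moves beyond the scatter.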